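The compounds below may be only part of what the source reports. "The series", "measured", "known", "first", "only" and "open" are said of these compounds alone.

Measured so far in a functional assay on NCI-H460 cells (Homo sapiens) for cytotoxicity, read by sulforhodamine B assay, with a stated time of 48 h, tested at 1 uM; on this read-out higher numbers stand for a weaker effect at the one concentration tested and lower numbers for a stronger effect:
compound 1 `COc1cc(-c2cc(/C=C/C(=O)c3ccc(N)cc3)[nH]n2)cc(OC)c1OC` gives 78%
compound 2 `COc1ccc(-c2cc(/C=C/C(=O)c3ccc(N)cc3)[nH]n2)cc1OC` gives 94%
compound 3 `COc1cc(C(=O)/C=C/c2cc(-c3cc(OC)c(OC)c(OC)c3)n[nH]2)cc(OC)c1OC` gives 89%

Compound 1 and compound 2 share one core and differ in a single place: hydrogen in place of methoxy on an aromatic carbon. That change produced a number 16 percentage points higher from compound 1 to compound 2 (beyond the scatter), a weaker effect at the tested concentration. Compound 3 is built on a different core, and the difference between the two cores is not broken down here. The values of compound 3 and compound 2 lie within the scatter of each other, so nothing can be said about their order, while the values of compound 3 and compound 1 differ by more than the scatter.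

Compound 4 `COc1ccc(-c2cc(/C=C/C(=O)c3cc(OC)c(OC)c(OC)c3)[nH]n2)cc1OC` has not yet been measured. It differs from compound 3 by the same change seen between compound 1 and compound 2, namely (hydrogen in place of methoxy on an aromatic carbon), at a place described in exactly the same words. Because a number 16 percentage points higher from compound 1 to compound 2 (beyond the scatter) was a modest weakening on the core of compound 1, a step of similar size is expected on the core of compound 3, a number 9 percentage points higher from compound 3 to compound 4 (within the scatter). Compound 4 is therefore estimated at 98%, with a likely range from 86% to 108%.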

Compound 4, a percentage reported as activity, at one concentration (the size of the read-out at that concentration, not a potency): 52%
Compound 4: middle estimate off by 46 percentage points, on the high side; measured number below the stated range.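

In this assay, hydrogen in place of methoxy on an aromatic carbon gave a number 37 percentage points lower from compound 3 to compound 4 (beyond the scatter) and so a stronger effect at the one concentration tested, whereas the same change weakened the effect on the core of compound 1, and the two steps clearly differ: the same change on two cores in this assay, a number 16 percentage points higher (beyond the scatter) from compound 1 to compound 2 and a number 37 percentage points lower (beyond the scatter) from compound 3 to compound 4, 53 percentage points apart, beyond the scatter of two such steps.
In this series, then, the result of this change on one core cannot be carried over to the other, in either size or direction. The two pairs do not show which feature of the cores lies behind the difference, they give no rule for any further core, and a reading at one concentration is not a potency.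

The compounds shown have only methoxy or hydrogen at the changed place, so it stays open how a hydroxyl group or a chlorine atom there would read on either core. Going by these compounds, it also stays open whether a third core would follow compound 1 and compound 2, or compound 3 and compound 4, or neither pair.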